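The source may report more compounds than this note shows. Statements on the series, on what has been measured and on what is new or still open speak of the compounds shown alone.

Going by the values given here, on a physicochemical assay for solubility (on this read-out lower numbers stand for lower solubility and higher numbers for higher solubility), three compounds have numbers so far. Compound 1 `O=S(=O)(Nc1ncccn1)c1ccc2c(c1)OCC[C@@H]2c1ccc(C(F)(F)F)cc1-c1ccc(F)nc1` gives 408000 nM on this read-out. Compound 2 `CN1CCN(c2cc(C(F)(F)F)ccc2[C@H]2CCOc3cc(S(=O)(=O)Nc4nccs4)ccc32)CC1` gives 176000 nM on the same read-out. Compound 3 `O=S(=O)(Nc1nccs1)c1ccc2c(c1)OCC[C@H]2c1ccc(C(F)(F)F)cc1-c1nccs1` gives 7000 nM as the lowest of the three, with its gaps to both others beyond the scatter. Compound 4 `O=S(=O)(Nc1nccs1)c1ccc2c(c1)OCC[C@H]2c1ccc(C(F)(F)F)cc1-n1ccnn1` differs from compound 3 in one place, on an aromatic carbon: 1H-1,2,3-triazol-1-yl in place of 1,3-thiazol-2-yl on an aromatic carbon is the whole change, with 1H-1,2,3-triazol-1-yl in place of 1,3-thiazol-2-yl. Among the compounds with values here, no measured pair shows this swap, so any step is a judgement. Within the data shown here, with compound 3 at 7000 nM as the lowest number so far, a moderate rise is expected rather than a fall. The expected move is a 3.6-fold higher number from compound 3 to compound 4 (0.55 log units; beyond the scatter) on this assay as an estimate only. Compound 4 is estimated at 25000 nM with a range from 7000 nM to 100000 nM for now.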

Compound 4, solubility: 154000 nM
The estimate for compound 4 lay 6.2-fold (0.79 log units) below the measured number, and the stated range ends below it.
By their numbers in this assay, from the lowest: compound 3; then compounds 4 and 2 (each within the scatter of the next); then compound 1.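

In this assay, the group on this aromatic carbon, ortho to a large group, proves to matter: 1H-1,2,3-triazol-1-yl in place of 1,3-thiazol-2-yl gives a 22-fold higher number from compound 3 to compound 4 (1.34 log units; beyond the scatter) even though both are five-membered aromatic rings of equal heavy-atom count. Going by these compounds alone, this is the first step here that can be tied to a change in one place. No measurement at hand explains this step. Still open, from the compounds shown here alone, is how a nitrile or a carboxylic acid on this carbon would compare, and whether the same swap gives a similar step on another core.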